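Naphthalen-2-yl in place of phenoxyethyl on the imidazole acid

A few compounds are considered here, and "the series" means these few. Any claim that something is new, unique, unknown or untested is made for them only; others in the source may bear on it.

Measured so far:
compound 1, `O=C(O)/C=C/c1ccc(Cn2cccn2)cc1OCCc1ccc2ccccc2c1`: 2900 nM
compound 2, `O=C(O)/C=C/c1ccc(Cn2ccnc2)cc1OCCCCOc1ccccc1`: > 10000 nM

Two compounds have been examined in an assay on CHO cells for displacement of a labelled ligand from prostaglandin E2 receptor EP1 subtype (Mus musculus), read by scintillation counting; a lower number here means a stronger inhibitor, a higher number a weaker inhibitor. Compound 1 `O=C(O)/C=C/c1ccc(Cn2cccn2)cc1OCCc1ccc2ccccc2c1` gives 2900 nM. Compound 2 `O=C(O)/C=C/c1ccc(Cn2ccnc2)cc1OCCCCOc1ccccc1` gives only a limit in this assay, > 10000 nM, so its standing is known no more closely than that it sits at the cut-off (the limit of > 10000 nM in this assay, at which 1 of the 2 values shown sits). Compound 3 `O=C(O)/C=C/c1ccc(Cn2ccnc2)cc1OCCc1ccc2ccccc2c1` has not yet been measured. It differs from compound 2 in a single place: naphthalen-2-yl in place of 2-phenoxyethyl on a saturated chain carbon, two bonds along the chain from an oxygen on an aromatic ring.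

Among the measured compounds shown here, no step between the two measured compounds is on record, so the size of this change has to be judged from the two values alone. Compound 1 carries the same naphthalen-2-yl group on its chain as compound 3 and gives a number under the cut-off, whereas compound 2 with the 2-phenoxyethyl chain reached only the limit. The step is therefore expected to run toward stronger inhibition, an at least 2.5-fold lower number from compound 2 to compound 3 (0.39 log units; beyond the scatter), beyond the usual scatter. Compound 3 is estimated at 4000 nM, with a range of 1000 nM to 15000 nM.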

Compound 3, inhibition constant: > 10000 nM
Compound 3: only a limit was reported (the forecaster's own chance of this, stated with the estimate: 25%); at least 2.5-fold (0.39 log units) between middle value and limit.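

Among the compounds shown here, with naphthalen-2-yl held on the chain, the one readable change is at the ring on the saturated chain carbon bound to an aromatic carbon: in this assay, 1H-imidazol-1-yl in place of 1H-pyrazol-1-yl gives an at least 3.4-fold higher number from compound 1 to compound 3 (0.53 log units; beyond the scatter). Among these compounds, then, naphthalen-2-yl on the chain does not bring the imidazole acid to a measurable number, and the only value under the cut-off belongs to the pyrazole compound 1. The exchange of 2-phenoxyethyl for naphthalen-2-yl cannot be read, since compound 2 and compound 3 both give only a limit: the limit of > 10000 nM in this assay, at which 2 of the 3 values shown sit.

How far compound 2 and compound 3 lie past that limit stays open, as does what 2-phenoxyethyl would do on the pyrazole side, where compound 1 has no partner among the compounds shown. Also open, on these data alone, is whether a 1H-1,2,4-triazol-1-yl group in place of the imidazole, or a longer chain carrying the naphthalen-2-yl group, would give a number under the cut-off.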